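Aryl for Alkyl on a Triazole: Expecting Another Limit

The source may report more compounds than this note shows. Statements on the series, on what has been measured and on what is new or still open speak of the compounds shown alone.

Compound 1 `CCCCCCc1cn(-c2ccc(O)c(C(=O)N3CCCCC3)c2)nn1` was tested in a functional assay on RAW264.7 cells (Mus musculus) for inhibition, read by Griess assay, with a stated time of 20 h; a higher number here means a weaker inhibitor, a lower number a stronger inhibitor. In this assay compound 1 gives only the assay limit, > 20000 nM. Compound 2 `O=C(c1cc(-n2cc(-c3cccc(Cl)c3)nn2)ccc1O)N1CCCCC1` carries one change on the core of compound 1, (3-chlorophenyl in place of hexyl on an aromatic carbon). In this assay compound 2 likewise gives only a limit, > 20000 nM. The step that the two limits leave unreadable from compound 1 to compound 2 therefore cannot be sized, since both ends sit at the limit of > 20000 nM in this assay, at which 3 of the 3 values shown sit. Compound 3 `CCCCCCc1cn(-c2ccc(C(=O)NCCC)c(O)c2)nn1` has a different core; how it differs from the core of compound 1 is not broken down here. In this assay compound 3 also gives only a limit, > 20000 nM. Compound 4 `CCCNC(=O)c1ccc(-n2cc(-c3cccc(Cl)c3)nn2)cc1O` applies the same change to compound 3, (3-chlorophenyl in place of hexyl on an aromatic carbon). With every measured value at the limit, the step that the limit leaves unreadable from compound 3 to compound 4 is expected to be small or unreadable. The estimate for compound 4 in this assay is 30000 nM, between 12000 nM and 100000 nM, most likely reported again only as a limit.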

Compound 4, half-maximal inhibitory concentration: > 20000 nM
Compound 4: only a limit was reported; the forecaster's own chance of this, stated with the estimate: 85%; the middle value does not contradict the limit.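

Compound 4 also gives only a limit in this assay, so no step can be read from compound 3 to compound 4: the limit of > 20000 nM in this assay, at which 4 of the 4 values shown sit. The compounds shown leave open how 3-chlorophenyl and hexyl compare on either core.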